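The compounds below may be only part of what the source reports. "The series", "measured", "known", "first", "only" and "open" are said of these compounds alone.

Measured so far:
compound 1 `COc1cccc(COc2ccc(-c3nn(CCC#N)c(=S)o3)cc2)c1` — in an assay for inhibition of Amine oxidase [flavin-containing] A (Rattus norvegicus) (on this read-out lower numbers stand for stronger inhibition and higher numbers for weaker inhibition), compound 1 gives 8100 nM.
compound 2 `N#CCCn1nc(-c2ccc(OCc3ccc(Cl)cc3)cc2)oc1=S` — in this assay compound 2 gives 2700 nM.

Within the data shown here, compound 2 stands as the lowest of the two numbers in hand; the only neighbour is compound 1, and the step of a 3.0-fold lower number from compound 1 to compound 2 (0.48 log units; beyond the scatter) separates them beyond the scatter. Among the measured compounds shown here, that single step is the only comparison so far that touches the benzyl ether ring, and it concerns the 4-chlorophenyl against 3-methoxyphenyl exchange, not the one now in question.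

Compound 3 `N#CCCn1nc(-c2ccc(OCc3ccc([N+](=O)[O-])cc3)cc2)oc1=S` carries the change (nitro in place of chloro on an aromatic carbon). For the measured compounds named here, no measured pair shows a chloro-to-nitro exchange, so the step from compound 1 to compound 2 bears on it only in showing that a substituent on this ring can move the number by a modest amount. Going by the values given here, with no closer precedent, the expectation for compound 3 is a step of no change at the digits printed from compound 2 to compound 3 (within the scatter) in this assay, not beyond the scatter in either direction. Compound 3 is therefore estimated at 2700 nM, with a range from 900 nM to 8000 nM.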

Compound 3, half-maximal inhibitory concentration: 2600 nM
For compound 3 the middle estimate is 1.0-fold (0.02 log units) above the measured one, and the stated range covers the measured number.
By their numbers in this assay, from the lowest: compounds 3 and 2 (each within the scatter of the next); then compound 1.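

In this assay, nitro in place of chloro gives a 1.0-fold lower number from compound 2 to compound 3 (0.02 log units; within the scatter), so at this place, para to a large group, three heavy atoms with two hydrogen-bond acceptors replace a single chlorine with no change beyond the scatter. Against the 3-methoxyphenyl group of compound 1, the 4-nitrophenyl group gives a 3.1-fold lower number from compound 1 to compound 3 (0.49 log units; beyond the scatter), so the lower number seen with 4-chlorophenyl is not particular to chloro. No measurement at hand accounts for either step.

Still open, on these data alone, is whether the step away from compound 1 follows the substituent itself or its place on the ring, which a 4-methoxyphenyl group would separate. An amine or a carboxylic acid at this place would show whether the same level holds beyond chloro and nitro.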